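The compounds below may be only part of what the source reports. "The series", "measured", "known", "first", "only" and "open" are said of these compounds alone.

Among the measured compounds shown here, compound 2 `COC(=O)Nc1nc2cc(C(=O)c3cc(CC(=O)O)cs3)ccc2[nH]1` gives 2000 nM in a functional assay on B16 cells (Mus musculus) for inhibition (a higher number here means a weaker inhibitor, a lower number a stronger inhibitor), the highest of the two numbers so far; compound 1 `COC(=O)Cc1csc(C(=O)c2ccc3[nH]c(NC(=O)OC)nc3c2)c1` gives 40 nM, and the single measured step, a 50-fold higher number from compound 1 to compound 2 (1.70 log units; beyond the scatter), is large. Compound 3 `COC(=O)Nc1nc2cc(C(=O)c3cc(CNC(=O)OC(C)(C)C)cs3)ccc2[nH]1` carries (tert-butoxycarbonyl)amino in place of carboxy on a saturated chain carbon bound to an aromatic carbon. For the measured compounds named here, no measured step covers this change; the only bearing is indirect, in that the step from compound 1 to compound 2 shows how strongly the carboxy costs in this assay, so removing it again is expected to recover much of that loss. Compound 3 is therefore expected to give about 100 nM, within 20 nM to 600 nM, a step of a 20-fold lower number from compound 2 to compound 3 (1.30 log units; beyond the scatter).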

Compound 3, half-maximal inhibitory concentration: 500 nM
The estimate for compound 3 lay 5.0-fold (0.70 log units) below the measured number, and the stated range covers the measured number.
By their numbers in this assay, from the lowest: compound 1; then compound 3; then compound 2.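

In this assay, (tert-butoxycarbonyl)amino in place of carboxy on this saturated chain carbon bound to an aromatic carbon gives a 4.0-fold lower number from compound 2 to compound 3 (0.60 log units; beyond the scatter), so this replacement recovers only part of the loss seen with the carboxy. Against the methoxycarbonyl, the same group gives a 13-fold higher number from compound 1 to compound 3 (1.10 log units; beyond the scatter), so the methoxycarbonyl of compound 1 remains clearly ahead at this position. No evidence on the cause of either step is available. Still open, as far as these compounds go, is whether a free amine, or a longer chain ending in a methyl ester, would narrow the gap to compound 1.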